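Chain Extension in Aryloxy Acids: Expected Whole-Animal Potency

This account rests on a few compounds, and the source may have more. Where it says the series, first, only, none or still open, it means among the compounds named here.

Measured compounds:
compound 1, `CC(C)c1ccc(OC(Cc2ccc(Cl)cc2)C(=O)O)cc1`: 10 mg/kg
compound 2, `CC(C)(C)c1ccc(OC(Cc2ccc(Cl)cc2)C(=O)O)cc1`: 25 mg/kg
compound 3, `CCc1ccc(CC(C)(Oc2ccc(C(C)C)cc2)C(=O)O)cc1`: 0.1 mg/kg

In a functional assay on the whole organism for inhibition, with Rattus norvegicus as the target (a higher number here means that more compound is needed for the effect, a lower number that less compound is needed), compound 1 gives 10 mg/kg, and compound 2 gives 25 mg/kg. Compound 2 differs from compound 1 by methyl in place of hydrogen on a saturated chain carbon bound to an aromatic carbon and two saturated chain carbons, and this change produced a 2.5-fold higher number from compound 1 to compound 2 (0.40 log units; beyond the scatter). Compound 3 rests on a different core, and the difference between the two cores is not broken down here. In this assay compound 3 gives 0.1 mg/kg, the lowest number of the three, with its steps to compound 1 and compound 2 both beyond the scatter.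

Compound 4, `CCCc1ccc(CC(C)(Oc2ccc(C(C)C)cc2)C(=O)O)cc1`, is not yet measured. It differs from compound 3 by methyl in place of hydrogen on a saturated chain carbon, two bonds along the chain from an aromatic carbon. This is the same kind of change as that from compound 1 to compound 2, but the place is not the same: there the carbon was bound to an aromatic carbon and two saturated chain carbons, here it lies two bonds along the chain from an aromatic carbon. Among the measured compounds shown here, a step of similar modest size is expected, a 1.8-fold higher number from compound 3 to compound 4 (0.26 log units; within the scatter), because the one comparable change gave a 2.5-fold higher number from compound 1 to compound 2 (0.40 log units; beyond the scatter). Compound 4 is therefore estimated at 0.18 mg/kg in this assay, with a likely range from 0.05 mg/kg to 0.6 mg/kg.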

Compound 4, dose for half-maximal effect: 0.5 mg/kg
Compound 4: the middle estimate sits 2.8-fold (0.44 log units) below what was measured, and the stated range covers the measured number.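

In this assay the change from ethyl to propyl gives a 5.0-fold higher number from compound 3 to compound 4 (0.70 log units; beyond the scatter) and so moves the number in the same direction as the methyl in place of hydrogen did on the core of compound 1. Set side by side, the two steps do not differ by more than the scatter: the same change on two cores in this assay, a 2.5-fold higher number (0.40 log units; beyond the scatter) from compound 1 to compound 2 and a 5.0-fold higher number (0.70 log units; beyond the scatter) from compound 3 to compound 4, 2.0-fold (0.30 log units) apart, within the scatter of two such steps. Among the compounds shown here, this shows the change carrying over in direction and rough size between these two cores in this one assay, but it rests on only two pairs, the methyl does not enter at the same place in each, and so it shows neither that the step is independent of core or place nor why the number rises.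

On these data alone, whether a butyl chain at this place would raise the number further, and whether a hydroxyl or an amine on the same chain would act like the methyl, remains open. The compounds shown also leave open how the change would behave on a third core.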